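Microsomal stability of the shared core: compound 4 ahead

The compounds below may be only part of what the source reports. "The series", "measured", "known", "first", "only" and "open" are said of these compounds alone.

Measured so far in an ADME assay on microsomes from liver (Mus musculus) for metabolic stability, read by LC-MS, with NADPH named in the record, with a stated time of 60 min, tested at 1 uM, in the absence of a further agent; a higher number here means that more of the compound is left, a lower number that less of the compound is left:
compound 1, `CC(=O)N[C@@H]1CCN(c2cc(C)nn3c(-c4ccc(C#N)cc4)c(C)nc23)C1`: compound 1 gives > 95%, a limit of the assay.
compound 2, `COc1ccc(-c2c(C)nc3c(N4CC[C@@H](NC(C)=O)C4)cc(Cl)nn23)cc1OC`: compound 2 gives > 95%, a limit of the assay.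
compound 3, `COc1ccc(-c2c(C)nc3c(N4CC[C@@H](NC(=O)Nc5ccccc5)C4)cc(C)nn23)cc1OC`: compound 3 gives > 95%, a limit of the assay.

Compound 3 thus stands at the top of what this assay reports, and no number separates it from compound 1 or compound 2: all three sit at the limit of > 95% in this assay, at which 3 of the 3 values shown sit. For the measured compounds named here, no step between two measured compounds is available, so there is no measured guide to how a change on the amine nitrogen moves the read-out.

Compound 4, `COc1ccc(-c2c(C)nc3c(N4CC[C@@H](NS(=O)(=O)c5cccs5)C4)cc(C)nn23)cc1OC`, is the next member. It differs from compound 3 by (thiophen-2-yl)sulfonyl in place of phenylcarbamoyl on an amine nitrogen.

With every value shown at the limit of > 95% in this assay, at which 3 of the 3 values shown sit, the expected step of a number at least 7 percentage points lower from compound 3 to compound 4 (that floor lies within the scatter) is none beyond the scatter, though a small fall cannot be ruled out. Compound 4 is therefore expected to give about 88% in this assay, within 65% to 99%, with a fair chance that the assay again reports only its limit.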

Compound 4, percent of the compound remaining: > 95%
Compound 4: no number, only a limit (the forecaster's own chance of this, stated with the estimate: 55%); middle value at least 7 percentage points from the limit.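

Compound 4 gives > 95%, a limit and not a number. With compound 3 also reported only as a limit, no step can be read from compound 3 to compound 4. The compounds shown leave open whether any change on the amine nitrogen lowers the percent of compound remaining, as every value sits at one limit: the limit of > 95% in this assay, at which 4 of the 4 values shown sit.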